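Naphthalen-1-yl replacing 4-formylphenyl on a shared core

The compounds below may be only part of what the source reports. "The series", "measured", "known", "first", "only" and "open" are said of these compounds alone.

Compound 2 `O=Cc1ccc(-c2cn3ccnc3c(-c3ccc4ncn(Cc5ccccc5)c4c3)n2)cc1` gives 31.5% in a functional assay on SF-539 cells (Homo sapiens) for inhibition, read by sulforhodamine B assay, with a stated time of 48 h, tested at 10 uM (a higher number here means more inhibition at the concentration tested (going by the name of the read-out), a lower number less inhibition), the higher of the two numbers measured; compound 1 `CCc1ccc(-c2cn3ccnc3c(-c3ccc4ncn(Cc5ccccc5)c4c3)n2)cc1` gives 21.2%, and the step of a number 10.3 percentage points higher from compound 1 to compound 2 (beyond the scatter) lies beyond the scatter. Compound 3 `c1ccc(Cn2cnc3ccc(-c4nc(-c5cccc6ccccc56)cn5ccnc45)cc32)cc1` carries naphthalen-1-yl in place of 4-formylphenyl on an aromatic carbon. Going by the values given here, the one measured step, a number 10.3 percentage points higher from compound 1 to compound 2 (beyond the scatter), alters the group on the same aromatic carbon, yet a formyl differs from a second fused aromatic ring, so it bears only loosely on this change. A change of a number 6.5 percentage points lower from compound 2 to compound 3 (within the scatter) is therefore estimated, downward and within the scatter. Compound 3 is expected to give 25%, in the range 5% to 48%.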

Compound 3, a percentage reported as inhibition, at one concentration (the size of the read-out at that concentration, not a potency): 4.22%
Compound 3: middle estimate off by 20.8 percentage points, on the high side; the measured number lies below the stated range.
By their numbers in this assay, from the lowest: compound 3; then compound 1; then compound 2.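

Replacing 4-formylphenyl with naphthalen-1-yl on this aromatic carbon gives a number 27.3 percentage points lower from compound 2 to compound 3 (beyond the scatter) in this assay, and replacing 4-ethylphenyl gives a number 17 percentage points lower from compound 1 to compound 3 (beyond the scatter). The position therefore responds not only to the group carried on a phenyl ring but also to the exchange of that phenyl for two fused aromatic rings, and compound 3 stands below both phenyl compounds. No measurement here accounts for this fall. Open, from the compounds shown here alone, is how naphthalen-2-yl would compare with naphthalen-1-yl, and whether an amine or a carboxylic acid on the phenyl ring would exceed formyl.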